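The compounds below may be only part of what the source reports. "The series", "measured", "known", "first", "only" and "open" are said of these compounds alone.

The account follows three congeners tested in an ADME assay on MIA PaCa-2 cells (Homo sapiens) for cytotoxicity, read by MTT assay, with a stated time of 72 h; on this read-out higher numbers stand for weaker inhibition and lower numbers for stronger inhibition. Compound 1, with structure `COc1ccc(C2=C(c3cc(OC)c(OC)c(OC)c3)C(=O)CC2O[SiH2]C(C)(C)C)cc1OC`, sits at the assay limit in this assay, where it gives > 100 ug/mL, a limit rather than a number. Compound 2, `COc1ccc(C2=C(c3cc(OC)c(OC)c(OC)c3)C(=O)C(O[SiH2]C(C)(C)C)C2)cc1OC(C)C`, likewise returns a limit in this assay, > 100 ug/mL. Compound 3, `C=CCOc1cc(C2=C(c3cc(OC)c(OC)c(OC)c3)C(=O)C(O)C2)ccc1OC`, also stops at a limit in this assay, > 100 ug/mL. So far, then, every value sits at the limit of > 100 ug/mL in this assay, at which 3 of the 3 values shown sit, and no step between measured compounds can be read. Compound 4, `COc1cc(C2=C(c3ccccc3)C(O[SiH2]C(C)(C)C)CC2=O)cc(OC)c1OC`, differs from compound 1 in one place: phenyl in place of 3,4-dimethoxyphenyl on a double-bonded ring carbon. Among the measured compounds shown here, with no measured step to lean on, no shift beyond the usual scatter is expected; the step from compound 1 to compound 4 is estimated as a number no higher from compound 1 to compound 4 (the limit leaves the size open), most probably ending again at a limit. Compound 4 is therefore expected to give about 100 ug/mL in this assay, between 30 ug/mL and 300 ug/mL.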

Compound 4, half-maximal inhibitory concentration: > 100 ug/mL
Compound 4 gave a limit, no number (the forecaster's own chance of this, stated with the estimate: 70%); the middle value lies on the limit itself.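

Compound 4, like compound 1, stops at a limit, so no step can be read between them: the limit of > 100 ug/mL in this assay, at which 4 of the 4 values shown sit.

The compounds shown leave open how far phenyl in place of 3,4-dimethoxyphenyl shifts the result in this assay and what would bring a readable number.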